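Replacing 4-methoxyphenyl with cyclopentyl on the urea nitrogen

This account rests on a few compounds, and the source may have more. Where it says the series, first, only, none or still open, it means among the compounds named here.

In an ADME assay on Vero cells (Chlorocebus sabaeus) for cytotoxicity, read by MTT assay, with a stated time of 72 h (a lower number here means a stronger inhibitor, a higher number a weaker inhibitor), compound 1 `COc1ccc(NC(=O)NNC(=O)c2cc([N+](=O)[O-])cn2C)cc1` gives 328000 nM. Compound 3 `Cn1cc([N+](=O)[O-])cc1C(=O)NNC(=S)Nc1ccccc1F` gives 293000 nM, and compound 2 `COc1ccc(NC(=O)NNC(=O)c2cc([N+](=O)[O-])c[nH]2)cc1` gives 401000 nM. Compound 1 thus sits among three numbers that all lie within the usual scatter of one another, so no ranking among them can be read. Among the compounds with values here, the one single-point step that has been measured, hydrogen in place of methyl on an aromatic nitrogen, is a 1.2-fold higher number from compound 1 to compound 2 (0.09 log units; within the scatter), which shows that this part of the shared core can be altered without moving the number.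

Compound 4 `Cn1cc([N+](=O)[O-])cc1C(=O)NNC(=O)NC1CCCC1` differs from compound 1 in another place: cyclopentyl in place of 4-methoxyphenyl on an amide-type nitrogen. Within the data shown here, no measured pair in this set changes the group on the amide-type nitrogen, so there is no directly comparable step; the only guide is that the three measured numbers and the one measured step all stay inside the scatter. Because of a 1.2-fold higher number from compound 1 to compound 2 (0.09 log units; within the scatter) and the closeness of compound 3 at 293000 nM, a step of no more than the scatter is expected for compound 4, in either direction.

The expected step for compound 4 is a 1.0-fold lower number from compound 1 to compound 4 (0.01 log units; within the scatter). Compound 4 is therefore estimated at 320000 nM, within a range of 160000 nM to 640000 nM.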

Compound 4, half-maximal inhibitory concentration: 271000 nM
Compound 4: middle estimate off by 1.2-fold (0.07 log units), on the high side, within the range that was stated.
By their numbers in this assay, from the lowest: compounds 4, 3, 1 and 2 (each within the scatter of the next).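

In this assay the exchange of 4-methoxyphenyl for cyclopentyl on an amide-type nitrogen gives a 1.2-fold lower number from compound 1 to compound 4 (0.08 log units; within the scatter) and so extends the picture to a second place on the molecule, since the earlier measured step had touched only the aromatic nitrogen of the shared core. The change is also a large one in what is counted: a six-membered aromatic ring of carbon only and a hydrogen-bond acceptor leave, and a smaller five-membered non-aromatic ring of carbon only enters, yet the numbers of this pair stay within the scatter of each other, so for this pair neither the aromatic ring nor the methoxy oxygen is needed for a number of this size. Nothing in the data bears on why the two numbers stay together.

Going by these compounds, all four compounds lie within the scatter of their neighbours, so it remains open whether any group on this nitrogen can shift the number beyond the scatter. An amine or a carboxylic acid carried on a longer chain in place of cyclopentyl would be one such test, and its outcome cannot be told from the compounds shown.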